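The source may hold more compounds than are shown below. What is called first, only, known or untested is meant among the compounds shown, and "the series" means these compounds.

The measured compounds are compound 1 `O=C(/C=C/c1ccccn1)Nc1ccc2c(c1)COC2=O`, compound 2 `O=C(Nc1ccccc1)Nc1ccc2c(c1)COC2=O` and compound 3 `CN(C(=O)Nc1ccc2c(c1)COC2=O)c1ccccc1`. In a functional assay on cells (T-cell, Mus musculus) for inhibition (a higher number here means a weaker inhibitor, a lower number a stronger inhibitor), compound 1 gives 17900 nM and compound 2 gives 7090 nM. For compound 3 this assay reports only a limit, > 100000 nM. Compound 2 thus holds the lowest of the two numbers; compound 1 sits higher. The step of an at least 14-fold higher number from compound 2 to compound 3 (1.14 log units; beyond the scatter) is large, but it changes an amide-type nitrogen. Compound 4 `Cc1ccccc1NC(=O)Nc1ccc2c(c1)COC2=O` differs from compound 2 elsewhere: methyl in place of hydrogen on an aromatic carbon. Within the data shown here, no measured step touches that aromatic ring, so the nitrogen step offers no guide here, and no change beyond the scatter is expected; the expected step is a 1.1-fold higher number from compound 2 to compound 4 (0.05 log units; within the scatter). Compound 4 is therefore estimated at 8000 nM, between 3000 nM and 25000 nM.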

Compound 4, half-maximal inhibitory concentration: 900 nM
The estimate for compound 4 lay 8.9-fold (0.95 log units) above the measured number, outside the stated range (below it).
By their numbers in this assay, from the lowest: compound 4; then compound 2; then compound 1. At a limit, above all of these: compound 3.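

In this assay, the change from phenyl to 2-methylphenyl gives a 7.9-fold lower number from compound 2 to compound 4 (0.90 log units; beyond the scatter), so this aromatic ring responds to a single added methyl on a carbon ortho to a large group. In compound 3 a methyl on the amide-type nitrogen moved the number the opposite way, so among these compounds the place of the methyl decides the direction of the change. Nothing shown here explains the stronger inhibition of compound 4. As far as these compounds go, it remains open whether an ethyl, a methoxy or a chlorine on the same carbon would match the methyl, and how a methyl would act elsewhere on that ring.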